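A few compounds are considered here, and "the series" means these few. Any claim that something is new, unique, unknown or untested is made for them only; others in the source may bear on it.

Measured so far:
Compound 1 `Fc1ccc(F)c(-c2nc3ncccc3o2)c1`: 18%
Compound 2 `CSc1ccccc1-c1nc2ncccc2o1`: 21%

Both compounds were tested in a functional assay on the whole organism for inhibition, with Rattus norvegicus as the target, at a dose of 30 mg/kg; on this read-out higher numbers stand for more inhibition at the one dose given (going by the name of the read-out) and lower numbers for less inhibition. Among the compounds with values here, compound 2 sits at the top of the two numbers, but its only neighbour, compound 1, lies within the usual scatter of it, so the two compounds cannot be told apart on this read-out; neither can be said to give the higher inhibition in this assay. Within the data shown here, no step between measured compounds is available here, so the size that a single change on the aromatic ring can make to this assay is unknown from these data.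

Compound 3 `COc1ccccc1-c1nc2ncccc2o1` has not yet been measured. It differs from compound 2 in one place: methoxy in place of methylsulfanyl on an aromatic carbon. The shared core of both compounds is kept. Among the measured compounds shown here, with two numbers that are inside the scatter of each other and no known step to lean on, the expectation for this change is a step from compound 2 to compound 3 of no clear size in either direction, estimated as a number 1 percentage points lower from compound 2 to compound 3 (within the scatter) in this assay. Compound 3 is therefore expected to give about 20%, with a range from 5% to 40%.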

Compound 3, a percentage reported as inhibition, in the whole organism at one dose (the size of the read-out at that dose, not a potency): 9%
Beside the measured number, compound 3's estimate is 11 percentage points above it, within the range that was stated.
By their numbers in this assay, from the lowest: compounds 3, 1 and 2 (each within the scatter of the next, the first and the last beyond it).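

In this assay, putting methoxy in place of methylsulfanyl on an aromatic carbon, ortho to a group of 9 heavy atoms, gives a number 12 percentage points lower from compound 2 to compound 3 (beyond the scatter) and so provides the first difference in this small set that clearly exceeds the usual scatter. The two groups match in several simple counts: each has 2 heavy atoms, no ring, 0 hydrogen-bond donors, 1 hydrogen-bond acceptor and no net charge, and the swap of 1 sulfur for 1 oxygen is what separates them. The read-out at this position can therefore shift even when those counts stay the same, although no available measurement accounts for the drop.

This is a single step at one position, measured at one dose, so it gives neither a potency nor a trend across groups. As far as these compounds go, how an ethoxy group, a longer chain with sulfur in the same place, or an amine would behave at this position remains open, as does whether the same swap would have a similar effect on a different core.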